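The compounds below may be only part of what the source reports. "The series", "measured", "known", "first", "only" and "open" are said of these compounds alone.

Measured compounds:
- compound 1, `COc1cc2c(Oc3ccc(NC(=O)N/N=C/c4ccc(F)cc4Cl)cc3F)ccnc2cc1OCCCN1CCC(C)CC1`, with 1500 nM in a functional assay on MDA-MB-231 cells (Homo sapiens) for cytotoxicity, read by MTT assay, with a stated time of 72 h; on this read-out lower numbers stand for stronger inhibition and higher numbers for weaker inhibition
- compound 2, `COc1cc2c(Oc3ccc(NC(=S)N/N=C/c4ccc(F)c(F)c4)cc3F)ccnc2cc1OCCCN1CCCCC1`, with 1400 nM in this assay
- compound 3, `COc1cc2c(Oc3ccc(/C=N/NC(=O)Nc4ccc(F)c(F)c4)cc3F)ccnc2cc1OCCCN1CCCCC1`, with 960 nM in this assay

Compound 3 has the lowest of the three numbers in this assay, but its gaps to compound 2 and to compound 1 both fall within the usual scatter of repeated measurements, so the three compounds cannot be told apart on these values. Compound 1 carries a chloro-fluoro-substituted ring on a hydrazone carbon, and compound 2 a thiourea in place of the urea; neither pair with compound 3 differs in one place only, so their values are simply noted side by side.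

Compound 4, `COc1cc2c(Oc3ccc(/C=N/NC(=O)Nc4ccc(F)cc4Br)cc3F)ccnc2cc1OCCCN1CCCCC1`, differs from compound 3 in one place: 2-bromo-4-fluorophenyl in place of 3,4-difluorophenyl on an amide-type nitrogen. Within the data shown here, no step between measured compounds that isolates this exchange is available, so the expectation rests on the narrow spread of the three numbers, which cover two different aryl rings and two urea arrangements without moving beyond the scatter. The step of a 1.1-fold higher number from compound 3 to compound 4 (0.06 log units; within the scatter) is therefore expected to be small, in no firm direction, and probably not beyond the scatter. Compound 4 is estimated at 1100 nM in this assay, within a range of 400 nM to 3200 nM.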

Compound 4, half-maximal inhibitory concentration: 1000 nM
Compound 4: the middle estimate sits 1.1-fold (0.04 log units) above what was measured; low and high end bracket the measured number.
By their numbers in this assay, from the lowest: compounds 3, 4, 2 and 1 (each within the scatter of the next).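

Among these compounds, this is the first exchange that can be read in one place, and in this assay it amounts to a 1.0-fold higher number from compound 3 to compound 4 (0.02 log units; within the scatter) when 2-bromo-4-fluorophenyl stands in place of 3,4-difluorophenyl on an amide-type nitrogen. So, for this pair, moving from one halogenated phenyl ring to another, with one fluorine given up for one bromine at the same count of heavy atoms, leaves compound 3 and compound 4 indistinguishable on this read-out, something the earlier compounds, which differ in more than one place, could not show. No measurement in hand explains why the two compounds match, so the result stands as an observation about this one pair.

On these data alone, what remains open is whether this tolerance extends beyond halogenated phenyl rings, for instance to an unsubstituted phenyl, a pyridine ring, a methoxy group or a carboxylic acid on the same amide-type nitrogen. As far as these compounds go, it is equally open whether the same exchange would read alike with the thiourea of compound 2 or with the 4-methylpiperidine end of compound 1 in place of the piperidine of compound 3.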